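This account rests on a few compounds, and the source may have more. Where it says the series, first, only, none or still open, it means among the compounds named here.

Measured in a functional assay on A549 cells (Homo sapiens) for inhibition, read by MTT assay, with a stated time of 72 h; a lower number here means a stronger inhibitor, a higher number a weaker inhibitor:
Compound 1 `COc1ccccc1NC(=O)C1CCN(C/C=C/c2ccccc2)CC1`: > 100000 nM (a limit of the assay, not a number)
Compound 2 `O=C(Nc1cccc(Br)c1)C1CCN(C/C=C/c2ccccc2)CC1`: 16500 nM
Compound 3 `O=C(Nc1ccc(F)c(Br)c1)C1CCN(C/C=C/c2ccccc2)CC1`: 11700 nM

Compound 3 gives 11700 nM, and it stands level with compound 2 in this assay: the step between them is a 1.4-fold lower number from compound 2 to compound 3 (0.15 log units; within the scatter). Compound 1 is reported only as a limit. The next compound, compound 4 `O=C(Nc1ccccn1)C1CCN(C/C=C/c2ccccc2)CC1`, carries pyridin-2-yl in place of 3-bromo-4-fluorophenyl on an amide-type nitrogen.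

Going by the values given here, no measured step makes this exchange directly. The closest evidence comes from the two steps that change the group at the same place, an at least 6.0-fold lower number from compound 1 to compound 2 (0.78 log units; beyond the scatter) and an at least 8.5-fold lower number from compound 1 to compound 3 (0.93 log units; beyond the scatter). Both lie beyond the scatter, so the number in this assay does respond to this group. Adding fluoro alone, by contrast, made no change beyond the scatter. Compound 4 has no bromo group, and neither does compound 1, so a move towards a higher number, meaning a weaker inhibitor, of modest size is expected. The step expected is a 4.3-fold higher number from compound 3 to compound 4 (0.63 log units; beyond the scatter). For compound 4 the estimated value is 50000 nM, with an expected range from 15000 nM to 150000 nM. A report of only a limit would not be surprising.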

Compound 4, half-maximal inhibitory concentration: 89300 nM
Estimate against measurement, compound 4: 1.8-fold (0.25 log units) below, within the range that was stated.
By their numbers in this assay, from the lowest: compounds 3 and 2 (each within the scatter of the next); then compound 4. At a limit, above all of these: compound 1.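

In this assay, going by these compounds alone, pyridin-2-yl on the amide-type nitrogen gives a clear rise against both bromophenyl groups, a 7.6-fold higher number from compound 3 to compound 4 (0.88 log units; beyond the scatter) and a 5.4-fold higher number from compound 2 to compound 4 (0.73 log units; beyond the scatter), so compound 4 puts a size on this exchange, which the earlier steps, all starting from a limit, could give only as a floor. Against 2-methoxyphenyl the picture differs: an at least 1.1-fold lower number from compound 1 to compound 4 (0.04 log units; that floor lies within the scatter), a floor that does not separate compound 4 from compound 1. Compound 1 is reported only as a limit, not a number, and it is the only such value here: the limit of > 100000 nM in this assay, at which 1 of the 4 values shown sits.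

The exchange removes the bromo group and brings in a ring nitrogen in one step, so the compounds shown cannot say which of the two accounts for the rise. On these data alone, an unsubstituted phenyl or a bromopyridinyl group on the amide-type nitrogen would separate the two, and how an amine or a carboxylic acid on this ring would read in this assay also stays open.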